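This account rests on a few compounds, and the source may have more. Where it says the series, first, only, none or still open, it means among the compounds named here.

The series shares one core, varied only in the group on the carbonyl carbon of the piperazine amide. Compound 1 `CC(C)C[C@H](N)c1cc(C(F)(F)F)ccc1N1CCN(C(=O)COc2ccc3ccccc3c2)CC1` gives 2000 nM in an assay on HEK293 cells for displacement of a labelled ligand from Melanocortin receptor 4 (Homo sapiens); on this read-out higher numbers stand for weaker inhibition and lower numbers for stronger inhibition. Compound 2 `CC(C)C[C@H](N)c1cc(C(F)(F)F)ccc1N1CCN(C(=O)CCNC2CCCCC2)CC1` gives 4800 nM in this assay, and compound 3 `CC(C)C[C@H](N)c1cc(C(F)(F)F)ccc1N1CCN(C(=O)COc2ccc(O)cc2)CC1` gives 4600 nM. Within the data shown here, compound 3 thus stands second highest of the numbers measured so far: its value and that of compound 2 lie within the scatter of each other, while the step of a 2.3-fold higher number from compound 1 to compound 3 (0.36 log units; beyond the scatter) is beyond it.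

Compound 4 `COc1ccc(CC(C)C(=O)N2CCN(c3ccc(C(F)(F)F)cc3[C@@H](N)CC(C)C)CC2)cc1F` differs from compound 3 at that same carbonyl carbon: 1-(3-fluoro-4-methoxybenzyl)ethyl in place of (4-hydroxyphenoxy)methyl on a carbonyl carbon. Among the measured compounds shown here, the measured steps that bear on this position are a 2.4-fold higher number from compound 1 to compound 2 (0.38 log units; beyond the scatter), a 2.3-fold higher number from compound 1 to compound 3 (0.36 log units; beyond the scatter) and a 1.0-fold lower number from compound 2 to compound 3 (0.02 log units; within the scatter), so every change there has been modest, and the one aromatic group of greater heavy-atom count among them, in compound 1, carried the lowest number. Since compound 4 again brings a larger group with an aromatic ring and no hydrogen-bond donor, a modest lowering of about the size of the step of a 2.3-fold higher number from compound 1 to compound 3 (0.36 log units; beyond the scatter), in the opposite direction, seems likely. For compound 4 the expected step is therefore estimated as a 2.0-fold lower number from compound 3 to compound 4 (0.30 log units; within the scatter).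

Compound 4 is therefore estimated to give 2300 nM in this assay, within a range of 900 nM to 6000 nM.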

Compound 4, inhibition constant: 200 nM
The estimate for compound 4 lay 12-fold (1.06 log units) above the measured number; measured number below the stated range.
By their numbers in this assay, from the lowest: compound 4; then compound 1; then compounds 3 and 2 (each within the scatter of the next).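

In this assay the group on the carbonyl carbon can shift the number far more than the earlier modest steps suggested: 1-(3-fluoro-4-methoxybenzyl)ethyl gives a 23-fold lower number from compound 3 to compound 4 (1.36 log units; beyond the scatter) and a 24-fold lower number from compound 2 to compound 4 (1.38 log units; beyond the scatter), and both steps are large. The new group also improves on the previous lowest compound, with a 10-fold lower number from compound 1 to compound 4 (1.00 log units; beyond the scatter), so the larger naphthalen-2-yl group of compound 1 is not needed for a low number here. The groups exchanged between compound 3 and compound 4 each hold one six-membered aromatic ring of carbon only, so that ring alone does not account for the step. Nothing at hand gives a reason for this result.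

The entering group differs from the leaving group in several features at once, so the compounds shown do not tell whether the fluorine, the methoxy, the branching methyl or the loss of the ether oxygen and hydroxyl carries the step. They also leave open whether a plain benzyl group, or a 4-methoxybenzyl group without the fluorine, would keep the number near that of compound 4.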